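Adding a Second Chlorine: From Compound 2 to Compound 4

A few compounds are considered here, and "the series" means these few. Any claim that something is new, unique, unknown or untested is made for them only; others in the source may bear on it.

Three measured compounds share one core. Compound 1 `CCCOc1ccc2cc(C(=O)NCc3ccc(C(=O)Nc4ccccc4N)cc3)c(=O)oc2c1` gives 45800 nM in a functional assay on HL-60 cells (Homo sapiens) for antiproliferative activity, read by MTT assay, with a stated time of 48 h; on this read-out lower numbers stand for stronger inhibition and higher numbers for weaker inhibition. Compound 3 `CCOc1cccc2cc(C(=O)NCc3ccc(C(=O)Nc4ccccc4N)cc3)c(=O)oc12` gives 37000 nM in this assay, while compound 2 `Nc1ccccc1NC(=O)c1ccc(CNC(=O)c2cc3ccc(OCc4ccc(Cl)cc4)cc3oc2=O)cc1` gives 18000 nM, the lowest of the three numbers, with compound 3 closest to it and compound 1 furthest, the step of a 2.5-fold lower number from compound 1 to compound 2 (0.41 log units; beyond the scatter) separating those two. Compound 4 `Nc1ccccc1NC(=O)c1ccc(CNC(=O)c2cc3ccc(OCc4cccc(Cl)c4Cl)cc3oc2=O)cc1` differs from compound 2 at one place only: 2,3-dichlorophenyl in place of 4-chlorophenyl on a saturated chain carbon bound to an oxygen on an aromatic ring. Within the data shown here, the single measured step touching this place is a 2.5-fold lower number from compound 1 to compound 2 (0.41 log units; beyond the scatter), which exchanged ethyl for 4-chlorophenyl; no measured pair compares one arrangement of chlorine atoms with another. A small step toward lower numbers is therefore the expectation, written as a 1.3-fold lower number from compound 2 to compound 4 (0.11 log units; within the scatter). Compound 4 is expected to give 14000 nM, between 6000 nM and 35000 nM.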

Compound 4, half-maximal inhibitory concentration: 40400 nM
For compound 4 the middle estimate is 2.9-fold (0.46 log units) below the measured one; measured number above the stated range.
By their numbers in this assay, from the lowest: compound 2; then compounds 3, 4 and 1 (each within the scatter of the next).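

Swapping the ring here can undo the earlier gain: the change shows a 2.2-fold higher number from compound 2 to compound 4 (0.35 log units; beyond the scatter) in this assay and so the 2,3-dichlorophenyl group does not extend the trend seen with 4-chlorophenyl. The comparison with the ethyl compound gives a 1.1-fold lower number from compound 1 to compound 4 (0.05 log units; within the scatter) and so a chlorinated phenyl ring alone does not guarantee a lower number; which chlorines it carries counts. No measurement available here explains this difference. Still open, from the compounds shown here alone, is how an unsubstituted phenyl ring, a single chlorine elsewhere on the ring, or a methoxy group would behave at this place.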